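Swapping Fluoro for Methoxy on the Benzyl Ring

The source may hold more compounds than are shown below. What is called first, only, known or untested is meant among the compounds shown, and "the series" means these compounds.

Among the measured compounds shown here, compound 2 `N#Cc1c(NCc2cccc(F)c2)sc2c1CCN(C(=O)c1ccc(F)cc1)C2` carries the highest number of the two compounds measured so far. In a functional assay on Chem-3 cells for antagonist activity at metabotropic glutamate receptor 1 (Homo sapiens), read by fluorescence and calcium flux (a lower number here means a stronger inhibitor, a higher number a weaker inhibitor), compound 2 gives 2380 nM. For the measured compounds named here, its only neighbour, compound 1 `N#Cc1c(NCc2ccccc2)sc2c1CCN(C(=O)c1ccc(F)cc1)C2`, in this assay gives 600 nM, and the single measured step, a 4.0-fold higher number from compound 1 to compound 2 (0.60 log units; beyond the scatter), came from fluoro in place of hydrogen on an aromatic carbon. Compound 3 `COc1cccc(CNc2sc3c(c2C#N)CCN(C(=O)c2ccc(F)cc2)C3)c1` has not yet been measured. It differs from compound 2 in one place: methoxy in place of fluoro on an aromatic carbon. Going by the values given here, no measured step exchanges fluoro for methoxy, so the only step that bears on it, a 4.0-fold higher number from compound 1 to compound 2 (0.60 log units; beyond the scatter), shows merely that a group on this aromatic carbon can move the number by a modest amount. A step of a 1.6-fold lower number from compound 2 to compound 3 (0.20 log units; within the scatter) toward a lower number is therefore expected, with wide uncertainty. Compound 3 is estimated at 1500 nM, within a range from 400 nM to 6000 nM.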

Compound 3, half-maximal inhibitory concentration: 3090 nM
Estimate against measurement, compound 3: 2.1-fold (0.31 log units) below, within the range that was stated.
By their numbers in this assay, from the lowest: compound 1; then compounds 2 and 3 (each within the scatter of the next).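

In this assay fluoro and methoxy on this aromatic carbon cannot be told apart, as the exchange gives a 1.3-fold higher number from compound 2 to compound 3 (0.11 log units; within the scatter) and so does not separate the 3-fluorobenzyl and 3-methoxybenzyl compounds. Set against hydrogen, methoxy gives a 5.2-fold higher number from compound 1 to compound 3 (0.71 log units; beyond the scatter) and so shows, alongside a 4.0-fold higher number from compound 1 to compound 2 (0.60 log units; beyond the scatter) for fluoro, that two different groups on this carbon both give a higher number than hydrogen, with compound 1 the lowest of the three. Nothing available explains why these two groups land so close together. Still open, from the compounds shown here alone, is whether a group of another kind on this carbon, such as an amine, a carboxylic acid or a longer chain like ethoxy, would also give a number higher than that of compound 1. Also open, going by these compounds, is whether fluoro and methoxy would stay this close on the other carbons of the ring.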